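The source may hold more compounds than are shown below. What is called first, only, known or untested is meant among the compounds shown, and "the series" means these compounds.

Compound 1 `CCOCCOn1c(-c2cccc(C#N)c2)nc(C)c1C(=O)OCC` gives 6250 nM in a functional assay on a cell-free system (plasma, Oryctolagus cuniculus) for inhibition, with stated times of 5 min, 1 min and 6 min; a higher number here means a weaker inhibitor, a lower number a stronger inhibitor. Among the three measured compounds it holds the second highest number: compound 2 `CCOC(=O)c1c(C)nc(-c2cccc(C#N)c2)n1OCc1ccccc1` gives 5930 nM, a difference of a 1.1-fold lower number from compound 1 to compound 2 (0.02 log units; within the scatter), while compound 3 `CCOC(=O)c1c(C)nc(-c2cccc(C#N)c2)n1OCc1ccc(Br)cc1` gives 24600 nM, a difference of a 3.9-fold higher number from compound 1 to compound 3 (0.60 log units; beyond the scatter). Compound 4 `CCOC(=O)c1c(C)nc(-c2cccc(C#N)c2)n1OCc1ccc(C(=O)OC)cc1` differs from compound 1 by 4-(methoxycarbonyl)phenyl in place of ethoxymethyl on a saturated chain carbon bound to an oxygen on an aromatic ring. Going by the values given here, three steps bear on this change: a plain phenyl at the same place gave a 1.1-fold lower number from compound 1 to compound 2 (0.02 log units; within the scatter), a 4-bromophenyl gave a 3.9-fold higher number from compound 1 to compound 3 (0.60 log units; beyond the scatter), and adding bromo to that phenyl gave a 4.1-fold higher number from compound 2 to compound 3 (0.62 log units; beyond the scatter). A substituted phenyl here has so far weakened inhibition, so compound 4 is expected to show a modest rise, a 2.4-fold higher number from compound 1 to compound 4 (0.38 log units; beyond the scatter). The estimated value for compound 4 is 15000 nM, within 6000 nM to 40000 nM.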

Compound 4, half-maximal inhibitory concentration: 9470 nM
For compound 4 the middle estimate is 1.6-fold (0.20 log units) above the measured one; the measured number falls inside the stated range.
By their numbers in this assay, from the lowest: compounds 2, 1 and 4 (each within the scatter of the next); then compound 3.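

The step of a 1.5-fold higher number from compound 1 to compound 4 (0.18 log units; within the scatter) shows that 4-(methoxycarbonyl)phenyl can take the place of ethoxymethyl on this saturated chain carbon without a change beyond the scatter. The step of a 1.6-fold higher number from compound 2 to compound 4 (0.20 log units; within the scatter) likewise shows that adding methoxycarbonyl to the plain phenyl leaves the number within the scatter, so a substituent on this phenyl does not always weaken inhibition. Bromo stands apart from methoxycarbonyl, as a 2.6-fold lower number from compound 3 to compound 4 (0.41 log units; beyond the scatter) shows.

Nothing available explains why these two substituents differ. On these data alone, whether an amine or a carboxylic acid in their place would behave like methoxycarbonyl or like bromo remains open.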